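Ring size at the thiocarbonyl nitrogen in a pyridinyl amidrazone series

The source may hold more compounds than are shown below. What is called first, only, known or untested is meant among the compounds shown, and "the series" means these compounds.

Two compounds of the series carry a measurement in a functional assay on A-375 cells (Homo sapiens) for cytotoxicity, read by MTT assay, with a stated time of 72 h, tested at 1 uM; a higher number here means more inhibition of growth at the concentration tested, a lower number less inhibition of growth. Compound 2 `N/C(=N\NC(=S)N1CCCCC1)c1ccccn1` gives 72.5%. Compound 1 `N/C(=N\NC(=S)N1CCCC1)c1ccc(F)cn1` gives 57.9%. Compound 2 thus stands highest of the two numbers, and its nearest neighbour, compound 1, lies lower by a margin beyond the usual scatter; compound 1 and compound 2 differ in two places at once, so no single step can be read from this pair.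

Compound 3 `N/C(=N\NC(=S)N1CCCC1)c1ccccn1` is the next compound to be measured in this assay. Relative to compound 2 the change is pyrrolidin-1-yl in place of piperidin-1-yl on a thiocarbonyl carbon. Among the compounds with values here, no measured pair isolates this change, so the size of the step is not known. Compound 1 also carries pyrrolidin-1-yl and sits lower than compound 2, which suggests a downward step, though the fluorine on the pyridine of compound 1 makes that comparison uncertain. The expected step is a modest decrease, a number 9.5 percentage points lower from compound 2 to compound 3 (within the scatter). Compound 3 is estimated at 63%, with a range from 48% to 77%.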

Compound 3, percent growth inhibition at one concentration: 65.7%
Estimate against measurement, compound 3: 2.7 percentage points below; the measured number falls inside the stated range.
By their numbers in this assay, from the lowest: compounds 1, 3 and 2 (each within the scatter of the next, the first and the last beyond it).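

Working notes: in this assay the ring on the thiocarbonyl carbon can now be read as a single change, and pyrrolidin-1-yl in place of piperidin-1-yl gives a number 6.8 percentage points lower from compound 2 to compound 3 (within the scatter). Within the data shown here, the fluoro position can also be read alone for the first time, and hydrogen in place of fluoro on an aromatic carbon gives a number 7.8 percentage points higher from compound 1 to compound 3 (within the scatter), so neither change, taken singly, separates its two compounds in this read-out. No supporting information on the origin of either step is available.

Other groups on the thiocarbonyl carbon remain open, for instance a morpholin-4-yl ring, a seven-membered azepan-1-yl ring or an open-chain dimethylamino group, any of which would show whether the insensitivity seen with these two rings extends further. As far as these compounds go, the fluoro step is known only with pyrrolidin-1-yl on the thiocarbonyl carbon, so it is open whether it reads the same with piperidin-1-yl, and whether chloro or methoxy on that aromatic carbon would behave as fluoro does.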